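Dropping the chloro group from an aminochromone cytotoxic lead

A few compounds are considered here, and "the series" means these few. Any claim that something is new, unique, unknown or untested is made for them only; others in the source may bear on it.

Of the compounds shown here, two have been measured in a functional assay on HL-60 cells (Homo sapiens) for cytotoxicity, read by MTT assay, with a stated time of 48 h; on this read-out lower numbers stand for stronger inhibition and higher numbers for weaker inhibition. Compound 1, `Nc1oc2ccc(Cl)cc2c(=O)c1/C=N/NCCO`, gives 6600 nM in this assay. Compound 2, `O=c1c(/C=N/Nc2cc(Cl)ccc2Cl)coc2ccccc12`, gives 265000 nM in this assay, a gap that lies well beyond the usual scatter, so compound 1 stands as the more potent of the two measured compounds. Compound 3, `Nc1oc2ccccc2c(=O)c1/C=N/NCCO`, has not been measured yet. It differs from compound 1 in one place: hydrogen in place of chloro on an aromatic carbon. Among the compounds with values here, no pair of measured compounds differing in a single place exists here, so this change has no measured precedent. Removing a chloro group from the shared core is expected to cost some potency, but probably not much. The step of a 1.8-fold higher number from compound 1 to compound 3 (0.26 log units; within the scatter) is therefore expected to be small, towards a higher number. Compound 3 is estimated to give about 12000 nM in this assay, with a plausible range from 4500 nM to 35000 nM.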

Compound 3, half-maximal inhibitory concentration: 48500 nM
Compound 3: the middle estimate sits 4.0-fold (0.61 log units) below what was measured; measured number above the stated range.
By their numbers in this assay, from the lowest: compound 1; then compound 3; then compound 2.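

In this assay, replacing chloro with hydrogen gives a 7.3-fold higher number from compound 1 to compound 3 (0.87 log units; beyond the scatter), so this one place on the shared core clearly affects the read-out. Within the data shown here, this is the first measured single-place step in the set, and it shows that exchanging one chlorine atom, with no ring, hydrogen-bond donor, hydrogen-bond acceptor or net charge involved, is enough to weaken inhibition beyond the usual scatter. Nothing available explains why the chloro compound is the stronger of this pair.

As far as these compounds go, with only chloro and hydrogen compared here, it remains open whether fluoro, bromo, methyl or methoxy at the same carbon would match compound 1, fall nearer compound 3 or go beyond both. A single pair also cannot show whether the step would be of similar size with a longer chain in place of the side chain shared by these two compounds.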